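The source may hold more compounds than are shown below. What is called first, only, known or untested is meant among the compounds shown, and "the series" means these compounds.

Measured so far:
Compound 1 `ClCc1ccccc1Cn1cnc2c(Cl)nc(Cl)nc21` gives 2230 nM in a functional assay on A549 cells (Homo sapiens) for cytotoxicity, read by sulforhodamine B assay, with a stated time of 48 h; on this read-out higher numbers stand for weaker inhibition of growth and lower numbers for stronger inhibition of growth.
Compound 2 `ClCc1ccccc1Cn1cnc2c(Cl)ncnc21` gives 7760 nM in this assay.
Compound 3 `ClCc1ccccc1Cn1cnc2ncnc(Cl)c21` gives 4460 nM in this assay.

Compound 2 stands at the highest number of the three, so it is the weakest growth inhibitor of the set on this read-out, though its gap to compound 3 lies within the scatter and no order between those two can be claimed. Among the measured compounds shown here, the one step that crosses the scatter is a 3.5-fold higher number from compound 1 to compound 2 (0.54 log units; beyond the scatter), a modest loss of growth inhibition on removing a chloro group from the shared core.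

Compound 4 `Nc1nc(Cl)c2ncn(Cc3ccccc3CCl)c2n1` is the next member. Relative to compound 2 the change is amino in place of hydrogen on an aromatic carbon. For the measured compounds named here, no measured step bears on this change: the single step in hand removes a chloro group rather than adding an amino group, so it gives no direction for the present change. With nothing to go on beyond the shared core and the narrow spread of the three values, the expectation in this assay is a step of no more than the scatter, in no set direction. For compound 4 the expected step is a 1.1-fold lower number from compound 2 to compound 4 (0.04 log units; within the scatter). Compound 4 is therefore estimated at 7000 nM, with a range from 2500 nM to 20000 nM.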

Compound 4, concentration for 50% growth inhibition: 21900 nM
The estimate for compound 4 lay 3.1-fold (0.50 log units) below the measured number; the measured number lies above the stated range.
By their numbers in this assay, from the lowest: compounds 1, 3 and 2 (each within the scatter of the next, the first and the last beyond it); then compound 4.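

In this assay, the position between two ring nitrogen atoms now has three groups to compare, and amino in place of hydrogen gives a 2.8-fold higher number from compound 2 to compound 4 (0.45 log units; beyond the scatter), a modest loss of growth inhibition. The earlier step showed only that hydrogen in place of chloro at this position raised the number, so this result adds a second step upward from hydrogen, and the position responds to a group that adds a hydrogen-bond donor as well as to the loss of chloro. The widest step at this position is amino in place of chloro, with a 9.8-fold higher number from compound 1 to compound 4 (0.99 log units; beyond the scatter), giving the order chloro, hydrogen, amino from the lowest number to the highest across these three compounds only, and nothing at hand accounts for that order.

Three groups at one position give no general trend, and methylamino, dimethylamino, methoxy or fluoro at the same carbon could show whether the order extends beyond chloro, hydrogen and amino. On these data alone, it also remains open whether amino in place of hydrogen gives a step of similar size on the core of compound 3.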